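Back from a Nitrophenyl Triazole to an Anilide Arm

A few compounds are considered here, and "the series" means these few. Any claim that something is new, unique, unknown or untested is made for them only; others in the source may bear on it.

Compound 2 `CCOC(=O)C1=Cc2ccccc2OC1(OCc1cn(-c2ccc([N+](=O)[O-])cc2)nn1)C(F)(F)F` stands at the limit of > 150000 nM in a functional assay on HeLa cells (Homo sapiens) for inhibition, read by MTT assay, with a stated time of 24 h (a lower number here means a stronger inhibitor, a higher number a weaker inhibitor), which is a limit and not a number. Compound 1 `CCOC(=O)C1=Cc2ccccc2OC1(OCc1cn(CC(=O)Nc2cccc(Cl)c2)nn1)C(F)(F)F` gives 12300 nM in this assay. Among the measured compounds shown here, the single measured comparison is an at least 12-fold higher number from compound 1 to compound 2 (1.08 log units; beyond the scatter), which rests on (the limit of > 150000 nM in this assay, at which 1 of the 2 values shown sits). Compound 3 `CCOC(=O)C1=Cc2ccccc2OC1(OCc1cn(CC(=O)Nc2cccc(F)c2)nn1)C(F)(F)F` differs from compound 2 by ((3-fluorophenyl)carbamoyl)methyl in place of 4-nitrophenyl on an aromatic nitrogen, a change that largely undoes that measured step. A large drop is therefore expected from compound 2 to compound 3, an at least 10-fold lower number from compound 2 to compound 3 (1.00 log units; beyond the scatter). Compound 3 is estimated at 15000 nM in this assay, with a range from 5000 nM to 60000 nM.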

Compound 3, half-maximal inhibitory concentration: > 150000 nM
Compound 3: a limit, no number; the forecaster's own chance of this, stated with the estimate: 15%; middle value at least 10-fold (1.00 log units) away from the limit.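

Swapping only the halogen on the anilide arm matters here: fluoro in place of chloro on an aromatic carbon gives an at least 12-fold higher number from compound 1 to compound 3 (1.08 log units; beyond the scatter), so among these compounds the arm on the aromatic nitrogen does not by itself give a measurable value. In this assay compound 3 gives > 150000 nM, which is a limit and not a number. Compound 2 and compound 3 both stand at a limit, so the step between them cannot be read: the limit of > 150000 nM in this assay, at which 2 of the 3 values shown sit.

Going by these compounds, whether a bromo or a methyl group in place of that chloro keeps a measurable value remains open. On these data alone, how far compound 2 and compound 3 lie beyond the limit also remains open.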